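The source may report more compounds than this note shows. Statements on the series, on what has been measured and on what is new or still open speak of the compounds shown alone.

Measured compounds in a functional assay on HCC 2998 cells (Homo sapiens) for cytotoxicity, read by sulforhodamine B assay, with a stated time of 48 h; on this read-out lower numbers stand for stronger inhibition of growth and higher numbers for weaker inhibition of growth:

Compound 1, `ClCc1ccc(Cn2cnc3c(Cl)ncnc32)cc1`: 660 nM
Compound 2, `Nc1nc(Cl)c2ncn(Cc3ccc(CCl)cc3)c2n1`: 500 nM
Compound 3, `ClCc1ccccc1Cn1cnc2c(Cl)ncnc21`: 1660 nM

Compound 1 and compound 2 share one core and differ in a single place: amino in place of hydrogen on an aromatic carbon. In this assay that change gave a 1.3-fold lower number from compound 1 to compound 2 (0.12 log units; within the scatter), so the two numbers for compound 1 and compound 2 cannot be told apart with confidence. Compound 3 has the same atoms as compound 1, joined differently; the difference between the two cores is not broken down here. In this assay compound 3 gives the highest of the three numbers, and its gap to compound 1 and to compound 2 lies beyond the usual scatter.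

Compound 4, `Nc1nc(Cl)c2ncn(Cc3ccccc3CCl)c2n1`, has not yet been measured. It stands to compound 3 as compound 2 stands to compound 1: amino in place of hydrogen on an aromatic carbon. The description of the place is the same word for word in both cases, so this is the same change on a differently joined core. Because the earlier step gave a 1.3-fold lower number from compound 1 to compound 2 (0.12 log units; within the scatter), a step of similar small size is expected here, a 1.3-fold lower number from compound 3 to compound 4 (0.11 log units; within the scatter), with the understanding that a single within-scatter step is a thin basis. For compound 4 the estimated value in this assay is 1300 nM, expected to fall between 600 nM and 2800 nM.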

Compound 4, concentration for 50% growth inhibition: 3020 nM
For compound 4 the middle estimate is 2.3-fold (0.37 log units) below the measured one, and the stated range ends below it.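

In this assay, amino in place of hydrogen on an aromatic carbon gave a 1.8-fold higher number from compound 3 to compound 4 (0.26 log units; within the scatter), so the numbers for compound 3 and compound 4 cannot be told apart with confidence. Set beside the earlier step on the core of compound 1, this step does not differ from it by more than repeated measurements would be expected to: the same change on two cores in this assay, a 1.3-fold lower number (0.12 log units; within the scatter) from compound 1 to compound 2 and a 1.8-fold higher number (0.26 log units; within the scatter) from compound 3 to compound 4, 2.4-fold (0.38 log units) apart, within the scatter of two such steps. This shows that, across these two pairs, the change stays small on both cores and that the way the core is joined has no detectable bearing on its size, but it does not show that the change acts identically on both cores or that it would stay small on any other core in the series, and two steps within the scatter are a narrow basis for either reading.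

The compounds shown leave open how a group other than amino on that same aromatic carbon, such as a methylamino group or a hydroxyl group, would read in this assay. They also leave open whether the amino step would stay this small if the chloromethyl group were exchanged for a bromomethyl group or a plain methyl group.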